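Dichloroacetamide in place of chloroacetamide on a shared core

The source may report more compounds than this note shows. Statements on the series, on what has been measured and on what is new or still open speak of the compounds shown alone.

Compound 1 `O=C(CCl)Nc1ccc(SCC(=O)Nc2ccc(Br)cn2)cc1` gives 2100 nM in a functional assay on HeLa cells (Homo sapiens) for antiproliferative activity, read by MTT assay, with a stated time of 48 h; on this read-out higher numbers stand for weaker inhibition and lower numbers for stronger inhibition.
Compound 2 `O=C(CCl)Nc1ccc(SCC(=O)Nc2cccc(Cl)c2)cc1` reaches only the limit > 80000 nM in this assay.
Compound 3 `O=C(CCl)Nc1ccc(SCC(=O)Nc2ccccn2)cc1` gives 7800 nM in this assay.

Among these, compound 1 has the lowest number of the two that are numbers; the step to compound 3 is a 3.7-fold higher number from compound 1 to compound 3 (0.57 log units; beyond the scatter), and the value of compound 2 is a limit, as noted in the limit of > 80000 nM in this assay, at which 1 of the 3 values shown sits. The steps of an at least 38-fold higher number from compound 1 to compound 2 (1.58 log units; beyond the scatter) and an at least 10-fold lower number from compound 2 to compound 3 (1.01 log units; beyond the scatter) all concern the group on the amide-type nitrogen, not the acyl end of the core.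

Compound 4 `O=C(CSc1ccc(NC(=O)C(Cl)Cl)cc1)Nc1ccc(Br)cn1` differs from compound 1 at that acyl end: chloro in place of hydrogen on a saturated chain carbon bound to a carbonyl carbon and a chlorine atom. Among the compounds with values here, none of the measured steps touches this part of the molecule, so none bears directly on the change; they only show that the core of compound 1 tolerates variation elsewhere with numbers that stay in the low micromolar region. Within the data shown here, with no direct precedent, the expected step in this assay is small, at or near the scatter, with a slight lean toward a higher number. The estimate for compound 4 is therefore 3000 nM, in a range from 800 nM to 12000 nM, which is expected to correspond to the step of a 1.4-fold higher number from compound 1 to compound 4 (0.15 log units; within the scatter).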

Compound 4, half-maximal inhibitory concentration: > 80000 nM
Compound 4: a limit, no number; the forecaster's own chance of this, stated with the estimate: 5%; middle value at least 26-fold (1.42 log units) from the limit.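

Within the data shown here, the acyl end of the shared core, which no earlier step touched, proves to be far from silent: chloromethyl to dichloromethyl gives an at least 38-fold higher number from compound 1 to compound 4 (1.58 log units; beyond the scatter) in this assay. The value of compound 4 is a limit and not a number, so the full size of this step stays unread, and compound 4 now shares that limit with compound 2: the limit of > 80000 nM in this assay, at which 2 of the 4 values shown sit. One added chlorine atom, with no ring and no net charge, is thus enough to lose the number that compound 1 gives, and nothing shown says which property of the dichloromethyl group lies behind that.

Going by these compounds, what remains open is how narrow the demand at this position is, since the chloromethyl group of compound 1 is compared here only with dichloromethyl, and a bromomethyl group, a plain methyl group or a longer chain in its place could each fall on either side of the limit in this assay. Also open, on these data alone, is whether the same loss would appear on the pyridin-2-yl compound 3, which carries no bromo group.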